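The source may hold more compounds than are shown below. What is called first, only, known or untested is meant among the compounds shown, and "the series" means these compounds.

Compound 3, `Cc1nn(-c2nc(-c3ccc(Cl)c(Cl)c3)c(SC(C)C)s2)c(C(=O)O)c1-c1cccc(C(F)(F)F)c1`, gives 22000 nM in a functional assay on BJAB cells (Homo sapiens) for antiproliferative activity, with a stated time of 4 days (a lower number here means that less compound is needed, a higher number that more compound is needed for the effect), and so carries the highest of the three numbers measured. Its nearest neighbour is compound 1, `Cc1nn(-c2nc(-c3ccc(Cl)c(Cl)c3)c(SC(C)C)s2)c(C(=O)O)c1-c1cncc(C#N)c1`, with 20000 nM in this assay, and the gap a 1.1-fold higher number from compound 1 to compound 3 (0.04 log units; within the scatter) lies within the scatter. Within the data shown here, the one compound that stands apart is compound 2, `Cc1nn(-c2nc(-c3ccc(Cl)c(Cl)c3)c(SC(C)C)s2)c(C(=O)O)c1-c1ccc(Cl)cc1`, which gives 2500 nM; the step of an 8.8-fold higher number from compound 2 to compound 3 (0.94 log units; beyond the scatter) is the only one here beyond the scatter.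

Compound 4, `Cc1cc(C#N)cc(-c2c(C)nn(-c3nc(-c4ccc(Cl)c(Cl)c4)c(SC(C)C)s3)c2C(=O)O)c1`, differs from compound 3 by 3-cyano-5-methylphenyl in place of 3-(trifluoromethyl)phenyl on an aromatic carbon. The step that bears on this most directly is a 1.1-fold higher number from compound 1 to compound 3 (0.04 log units; within the scatter), since the group of compound 1 also carries a nitrile and that exchange moved the number only within the scatter. The other comparison, an 8.8-fold higher number from compound 2 to compound 3 (0.94 log units; beyond the scatter), concerns a chlorine-bearing ring that compound 4 does not carry. On this basis compound 4 is expected to stay close to compound 3, with a step of a 1.1-fold lower number from compound 3 to compound 4 (0.04 log units; within the scatter) in this assay. The estimate for compound 4 is 20000 nM, within a range from 7000 nM to 50000 nM.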

Compound 4, half-maximal effective concentration: 4800 nM
For compound 4 the middle estimate is 4.2-fold (0.62 log units) above the measured one; measured number below the stated range.
By their numbers in this assay, from the lowest: compounds 2 and 4 (each within the scatter of the next); then compounds 1 and 3 (each within the scatter of the next).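

Among these compounds, at this place on the five-membered aromatic ring with 2 nitrogen, this assay shows for the first time that a nitrile-bearing group can give a markedly lower number, with a 4.6-fold lower number from compound 3 to compound 4 (0.66 log units; beyond the scatter). A nitrile alone does not set the number, since the two nitrile-bearing groups are separated by a 4.2-fold lower number from compound 1 to compound 4 (0.62 log units; beyond the scatter), while 3-cyano-5-methylphenyl and 4-chlorophenyl cannot be told apart, with a 1.9-fold higher number from compound 2 to compound 4 (0.28 log units; within the scatter). No measurement shown here explains these steps.

The compounds shown leave open whether the methyl group or the ring of carbon only accounts for the step between the two nitrile-bearing groups, as the two features change together. They also leave open how an amine or a longer chain in place of that methyl group would read in this assay.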